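The source may report more compounds than this note shows. Statements on the series, on what has been measured and on what is new or still open speak of the compounds shown alone.

Of the compounds shown here, two have been measured in a functional assay on TSGH cells (Homo sapiens) for inhibition, with a stated time of 72 h; on this read-out lower numbers stand for stronger inhibition and higher numbers for weaker inhibition. Compound 1 `COc1cc(C(=O)c2cccc3cc[nH]c23)cc(OC)c1OC` gives 310 nM, while compound 2 `CCn1ccc2cc(C(=O)c3cc(OC)c(OC)c(OC)c3)ccc21` gives 41 nM, the lower of the two numbers and separated from the other by more than the scatter. Compound 3 `COc1cc(C(=O)c2ccc3c(ccn3CC(=O)O)c2)cc(OC)c1OC` has not yet been measured. It departs from compound 2 by a single change, carboxy in place of methyl on a saturated chain carbon bound to an aromatic nitrogen. Within the data shown here, no two measured compounds differ in only one place, so the data offer no direct guide to this change, and the expectation carries wide uncertainty. A clear weakening, towards a higher number, is expected, with an estimated step of a 29-fold higher number from compound 2 to compound 3 (1.47 log units; beyond the scatter). For compound 3 the estimated value is 1200 nM, with an expected range from 200 nM to 7000 nM.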

Compound 3, half-maximal inhibitory concentration: 548 nM
Beside the measured number, compound 3's estimate is 2.2-fold (0.34 log units) above it; the range from low to high includes it.
By their numbers in this assay, from the lowest: compound 2; then compounds 1 and 3 (each within the scatter of the next).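

In this assay, carboxy in place of methyl on a saturated chain carbon bound to an aromatic nitrogen gives a 13-fold higher number from compound 2 to compound 3 (1.13 log units; beyond the scatter), a large weakening. This is the first pair shown that differs in one place, and it shows that inhibition responds strongly to what is carried at this position, although compound 3 still gives a measured value of 548 nM. The data shown offer nothing that accounts for the size of this step.

The compounds shown leave open whether an amine or a primary amide on the same chain carbon would stay nearer to compound 2 or weaken inhibition to a similar degree. They also leave open whether a longer chain ending in the carboxylic acid would give a number different from that of compound 3.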